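The source may hold more compounds than are shown below. What is called first, only, known or untested is meant among the compounds shown, and "the series" means these compounds.

In a functional assay on NCI-H460 cells (Homo sapiens) for inhibition, read by MTT assay (on this read-out higher numbers stand for weaker inhibition and lower numbers for stronger inhibition), compound 1 `N#Cc1c(N)sc(C(=O)Nc2ccc(Cl)cc2)c1-c1ccccc1` gives 760 nM and compound 2 `CCOC(=O)c1c(NC(=O)CC#N)sc(C(=O)Nc2ccc(Cl)cc2)c1-c1ccccc1` gives 430 nM as its value. Compound 3 `N#Cc1c(N)sc(C(=O)Nc2ccccc2)c1-c1ccccc1` gives 9620 nM as the highest number of the three. Compound 4 `CCOC(=O)c1c(N)sc(C(=O)Nc2ccccc2)c1-c1ccccc1` differs from compound 3 by ethoxycarbonyl in place of cyano on an aromatic carbon. Going by the values given here, the one measured step (a 13-fold higher number from compound 1 to compound 3 (1.10 log units; beyond the scatter)) is large but concerns hydrogen in place of chloro, not this swap. Among the compounds with values here, compound 2 also carries ethoxycarbonyl, but no measured pair isolates the swap, so no clear shift in either direction is expected in this assay for this change. The expected step is a 1.4-fold lower number from compound 3 to compound 4 (0.14 log units; within the scatter) by this estimate. Compound 4 is estimated at 7000 nM within an expected range (1800 nM to 28000 nM).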

Compound 4, half-maximal inhibitory concentration: 8590 nM
For compound 4 the middle estimate is 1.2-fold (0.09 log units) below the measured one, and the stated range covers the measured number.
By their numbers in this assay, from the lowest: compounds 2 and 1 (each within the scatter of the next); then compounds 4 and 3 (each within the scatter of the next).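

In this assay, going by these compounds alone, putting ethoxycarbonyl in place of cyano gives a 1.1-fold lower number from compound 3 to compound 4 (0.05 log units; within the scatter), the first direct reading of a change at this position. On the shared core without the chloro, this position therefore takes the larger ethoxycarbonyl group with no change beyond the scatter. No evidence here explains this result. From the compounds shown here alone, it remains open whether the same swap would be as silent on a core that carries the chloro. Going by these compounds, it also remains open whether a carboxylic acid or a primary amide at this position would leave the number unchanged.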